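The source may hold more compounds than are shown below. What is called first, only, known or untested is meant among the compounds shown, and "the series" means these compounds.

This series concerns compounds built around a shared core that are tested in an assay on isolated protein for displacement of a labelled ligand from Apoptosis regulator Bcl-2 (Homo sapiens), read by fluorescence polarization; a lower number here means a stronger inhibitor, a higher number a weaker inhibitor. Compound 1, with the structure `CN(C)CC[C@H](CSc1ccccc1)Nc1ccc(S(=O)(=O)NC(=O)c2ccc(N3CCN(Cc4ccccc4-c4ccc(Cl)cc4)CC3)cc2)cc1`, serves as the starting point. In this assay compound 1 reaches the limit of the assay and reports < 1 nM, so only a limit is known for it rather than a number. Two related compounds stand alongside it. Compound 2, with the structure `CN(C)CC[C@H](CSc1ccccc1)Nc1ccc(S(=O)(=O)NC(=O)c2ccc(N3CCN(CC4=C(c5ccc(Cl)cc5)CCC(C)(C)C4)CC3)cc2)cc1[N+](=O)[O-]`, also reaches the limit in this assay and gives < 1 nM. Compound 3, with the structure `O=C(NS(=O)(=O)c1ccc(NCCSc2ccccc2)c([N+](=O)[O-])c1)c1ccc(N2CCN(Cc3ccccc3-c3ccc(Cl)cc3)CC2)cc1`, likewise reaches the limit in this assay and gives < 1 nM. For the measured compounds named here, all three values therefore sit at the limit of < 1 nM in this assay, at which 3 of the 3 values shown sit, and no step between measured compounds can be sized here.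

The compound not yet measured is compound 4, with the structure `CN(C)CC[C@H](CSc1ccccc1)Nc1ccc(S(=O)(=O)NC(=O)c2ccc(N3CCN(Cc4ccccc4-c4ccc(Cl)cc4)CC3)cc2)cc1S(=O)(=O)C(F)(F)F`. Its change from compound 1 is (trifluoromethyl)sulfonyl in place of hydrogen on an aromatic carbon. Because every measured compound sits at the limit of < 1 nM in this assay, at which 3 of the 3 values shown sit, the expected step from compound 1 to compound 4 in this assay is none beyond the scatter, and compound 4 is expected to reach the same limit. The estimate for compound 4 in this assay is 0.5 nM, with a range from 0.1 nM to 1.5 nM, which corresponds to an expected step that the limit leaves unreadable from compound 1 to compound 4.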

Compound 4, inhibition constant: < 1 nM
Compound 4 gave a limit, no number (the forecaster's own chance of this, stated with the estimate: 85%); the middle value does not contradict the limit.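

Compound 1 and compound 4 both give only a limit in this assay, so no step can be read between them for (trifluoromethyl)sulfonyl in place of hydrogen: the limit of < 1 nM in this assay, at which 4 of the 4 values shown sit.

The compounds shown leave open whether that replacement changes the strength of inhibition at all, and how far any of the four compounds differ from one another in this assay.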